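Urea-to-amide switch at the carbonyl of compound 2

The source may hold more compounds than are shown below. What is called first, only, known or untested is meant among the compounds shown, and "the series" means these compounds.

Measured so far:
compound 1, `O=C(Nc1cccc(-n2cc(-c3ccncc3)c(-c3cc(O)cc(Cl)c3)n2)c1)Nc1ccc(Cl)c(Cl)c1` — 93%
compound 2, `COc1cc(Cl)cc(-c2nn(-c3cccc(NC(=O)Nc4ccc(Cl)c(Cl)c4)c3)cc2-c2ccncc2)c1` — 99%

In a functional assay on MOLT-4 cells (Homo sapiens) for inhibition, read by sulforhodamine B assay, with a stated time of 48 h, tested at 0.01 uM (a lower number here means a stronger effect, a higher number a weaker effect of the compound at the concentration tested), compound 2 gives 99%. Among the measured compounds shown here, the only other measured compound, compound 1, gives 93% in this assay, and the step of a number 6 percentage points higher from compound 1 to compound 2 (within the scatter) is the sole measured step; it concerns a methyl in place of hydrogen on an oxygen on an aromatic ring and says nothing about the carbonyl end of the molecule.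

Compound 3, `COc1cc(Cl)cc(-c2nn(-c3cccc(NC(=O)c4cccc(C(F)(F)F)c4)c3)cc2-c2ccncc2)c1`, differs from compound 2 as follows: 3-(trifluoromethyl)phenyl in place of (3,4-dichlorophenyl)amino on a carbonyl carbon. For the measured compounds named here, no measured step touches the carbonyl carbon or its amide-type nitrogen, so no size or direction can be drawn from the series for this change. The expectation for compound 3 is therefore a step of a number 4 percentage points lower from compound 2 to compound 3 (within the scatter), not beyond the scatter, with a wide allowance for the untested change. Compound 3 is estimated at 95%, in the range 80% to 105%.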

Compound 3, a percentage reported as activity, at one concentration (the size of the read-out at that concentration, not a potency): 91%
For compound 3 the middle estimate is 4 percentage points above the measured one; low and high end bracket the measured number.
By their numbers in this assay, from the lowest: compounds 3, 1 and 2 (each within the scatter of the next).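

In this assay, among the compounds shown here, the first measured change at the carbonyl carbon, a number 8 percentage points lower from compound 2 to compound 3 (within the scatter), replaces (3,4-dichlorophenyl)amino with 3-(trifluoromethyl)phenyl and so turns the urea into an amide. Exchanging the aryl group and removing the nitrogen attached to the carbonyl carbon therefore gives no step beyond the scatter at the single concentration tested, although this one pair cannot show how far that holds for other groups here. No available evidence bears on this result.

The step changes the linking atom and the aryl substituents together, so their separate contributions remain unresolved. A (3,4-dichlorophenyl) group attached directly to the carbonyl carbon would separate them, while a piperidine or a short alkyl chain at the same place would test whether an aryl group is needed there at all.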